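Alkyl Branching on a Shared Core: Compound 4 Awaited

The compounds below may be only part of what the source reports. "The series", "measured", "known", "first", "only" and "open" are said of these compounds alone.

In a functional assay (aorta) with Oryctolagus cuniculus as the target (on this read-out lower numbers stand for tighter binding and higher numbers for weaker binding), three compounds have been measured:
compound 1 `CCCCc1nc2cccnc2n1Cc1cc(Cl)c(O)c(Cl)c1` gives 63.1 nM;
compound 2 `CCCc1nc2cccnc2n1Cc1cc(Cl)c(O)c(Cl)c1` gives 31.6 nM;
compound 3 `CCc1nc2c(C)ccnc2n1Cc1ccc(-c2ccccc2C(=O)O)cc1` gives 1.26 nM.

Compound 1 and compound 2 share one core and differ in one place: methyl in place of hydrogen on a saturated chain carbon, three bonds along the chain from an aromatic carbon. That step, a 2.0-fold higher number from compound 2 to compound 1 (0.30 log units; within the scatter), stays within the scatter of this assay, so the two values cannot be set in order. Compound 3 carries a different core, and the difference between the two cores is not broken down here; what can be said is that compound 3 gives the lowest number of the three, with compound 2 and compound 1 both well above it.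

Compound 4 `Cc1ccnc2c1nc(C(C)C)n2Cc1ccc(-c2ccccc2C(=O)O)cc1` has not yet been measured. It differs from compound 3 in this way: methyl in place of hydrogen on a saturated chain carbon bound to an aromatic carbon and a saturated chain carbon. This is the same kind of change as that from compound 2 to compound 1, with one difference around the place: in compound 4 the methyl enters on a saturated chain carbon bound to an aromatic carbon and a saturated chain carbon, whereas from compound 2 to compound 1 it entered three bonds along the chain from an aromatic carbon.

Among the compounds with values here, for this assay the expectation for compound 4 rests on the single earlier instance: because a 2.0-fold higher number from compound 2 to compound 1 (0.30 log units; within the scatter) lay within the scatter, a step of about a 1.4-fold higher number from compound 3 to compound 4 (0.15 log units; within the scatter) is expected from compound 3 to compound 4. On that basis compound 4 is estimated at 1.8 nM, between 0.5 nM and 6 nM.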

Compound 4, dissociation constant: 31.6 nM
For compound 4 the middle estimate is 18-fold (1.24 log units) below the measured one; measured number outside the range, above it.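

In this assay, the methyl entering on a saturated chain carbon bound to an aromatic carbon and a saturated chain carbon gives a 25-fold higher number from compound 3 to compound 4 (1.40 log units; beyond the scatter), so the change from ethyl to isopropyl is a large step on this core. The same kind of change therefore does not carry over in size from one core to the other: the same change on two cores in this assay, a 2.0-fold higher number (0.30 log units; within the scatter) from compound 2 to compound 1 and a 25-fold higher number (1.40 log units; beyond the scatter) from compound 3 to compound 4, 13-fold (1.10 log units) apart, beyond the scatter of two such steps. What this does not show is the source of the gap: the two steps differ in the place of the methyl as well as in the core, so they cannot separate the two, and two instances give no rule for the series.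

The compounds shown leave open how a longer chain, such as butyl, or a cyclopropyl group would read at the same place on the core of compound 3. They also leave open how isopropyl would read on the core of compound 1, a comparison that would set the methyl at the same place on both cores.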